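The source may report more compounds than this note shows. Statements on the series, on what has been measured and on what is new or still open speak of the compounds shown alone.

Series notes. In an ADME assay on HEK293 cells (Homo sapiens) for antiproliferative activity, read by MTT assay, with a stated time of 24 h (a lower number here means a stronger inhibitor, a higher number a weaker inhibitor), compound 1 `COc1ccc(-c2cc(C(=O)/C=C/c3ccccc3)nc3cc(-c4ccccc4)nn23)cc1OC` gives 64100 nM, compound 2 `COc1ccc(-c2cc(/C=C/C(=O)c3cc(OC)c(OC)c(OC)c3)nc3cc(-c4ccccc4)nn23)cc1OC` gives 35000 nM and compound 3 `COc1ccc(-c2cc(C(=O)/C=C/c3ccc(Cl)cc3)nc3cc(-c4ccccc4)nn23)cc1OC` gives 39100 nM. Compound 3 therefore sits second highest of the three numbers; its nearest neighbour is compound 2 and its furthest is compound 1, both within the scatter. Among the measured compounds shown here, the only single-point step measured, a 1.6-fold lower number from compound 1 to compound 3 (0.21 log units; within the scatter), also lies within the scatter. Compound 4 `COc1ccc(-c2cc(/C=C/C(=O)c3ccc(C)c(C)c3)nc3cc(-c4ccccc4)nn23)cc1OC` differs from compound 3 by 2-((3,4-dimethylphenyl)carbonyl)ethenyl in place of (2-(4-chlorophenyl)ethenyl)carbonyl on an aromatic carbon. For the measured compounds named here, no measured step covers this change, and compound 2 and compound 3 give values within the scatter of each other. The expected step is accordingly a 1.1-fold lower number from compound 3 to compound 4 (0.04 log units; within the scatter), nothing beyond the scatter. Compound 4 is estimated at 36000 nM, with a range of 18000 nM to 75000 nM.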

Compound 4, half-maximal inhibitory concentration: 46200 nM
For compound 4 the middle estimate is 1.3-fold (0.11 log units) below the measured one; the measured number falls inside the stated range.
By their numbers in this assay, from the lowest: compounds 2, 3, 4 and 1 (each within the scatter of the next).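

In this assay 3,4-dimethylphenyl in place of 3,4,5-trimethoxyphenyl on a carbonyl carbon gives a 1.3-fold higher number from compound 2 to compound 4 (0.12 log units; within the scatter) and thus no change beyond the scatter. Reversing the order of carbonyl and ethenyl at this position, next to the ring nitrogen, while also changing the aryl group, gives a 1.2-fold higher number from compound 3 to compound 4 (0.07 log units; within the scatter) and a 1.4-fold lower number from compound 1 to compound 4 (0.14 log units; within the scatter) and so also stays within the scatter. Nothing measured here offers an explanation for these results.

Still open, as far as these compounds go, is whether an amine or a carboxylic acid on this aryl ring would move the number beyond the scatter. Also open, from the compounds shown here alone, is the effect of reversing the linker alone, with the aryl group held constant.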